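From a Ring to an Isobutyl Ether

The source may hold more compounds than are shown below. What is called first, only, known or untested is meant among the compounds shown, and "the series" means these compounds.

Measured compounds:
compound 1 `C=CCc1cc(OC)c(OC(C)C(OC(C)C)c2ccc(O)c(OC)c2)c(OC)c1`, 82 nM in an assay on HEK293 cells for agonist activity at transient receptor potential cation channel subfamily M member 8 (Homo sapiens), read by fluorescence and calcium flux, with a stated time of 5 min; a higher number here means that more compound is needed for the effect, a lower number that less compound is needed
compound 2 `C=CCc1cc(OC)c(OC(C)C(O[C@H]2C[C@@H](C)CC[C@@H]2C(C)C)c2ccc(O)c(OC)c2)c(OC)c1`, 11 nM in this assay

Compound 2 stands lowest of the two numbers in this assay; compound 1 is the nearest, and the step of a 7.5-fold lower number from compound 1 to compound 2 (0.87 log units; beyond the scatter) is beyond the scatter. Compound 3 `C=CCc1cc(OC)c(OC(C)C(OCC(C)C)c2ccc(O)c(OC)c2)c(OC)c1` has not yet been measured. It differs from compound 2 in one place: a group of 4 heavy atoms (4 carbon; no ring) in place of a group of 10 heavy atoms (10 carbon; one six-membered non-aromatic ring of carbon only), on an oxygen on a saturated carbon. This change largely undoes what the step from compound 1 to compound 2 did, where a ring-bearing group took the place of a short chain on the same oxygen. Going by the values given here, only that one step bears on the question, and it was modest in size. Compound 3 is therefore expected to return toward the number of compound 1, with a step of a 5.5-fold higher number from compound 2 to compound 3 (0.74 log units; beyond the scatter) in this assay. The estimate for compound 3 is 60 nM, within a range from 25 nM to 150 nM.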

Compound 3, half-maximal effective concentration: 138 nM
Beside the measured number, compound 3's estimate is 2.3-fold (0.36 log units) below it; the range from low to high includes it.
By their numbers in this assay, from the lowest: compound 2; then compounds 1 and 3 (each within the scatter of the next).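

In this assay, isobutyl in place of the ring-bearing group gives a 13-fold higher number from compound 2 to compound 3 (1.10 log units; beyond the scatter), so the low number of compound 2 does not survive the loss of that group. Isobutyl in place of isopropyl gives a 1.7-fold higher number from compound 1 to compound 3 (0.23 log units; within the scatter), which lies within the scatter, so the two open chains on this oxygen cannot be told apart. Among these three compounds, only the group with the six-membered ring stands apart.

No supporting data are available to explain this difference. The compounds shown leave open whether the ring alone is enough, as a plain cyclohexyl group on this oxygen would test, whether a longer chain could match compound 2, and whether the three defined stereocentres of the ring-bearing group matter.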